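The source may report more compounds than this note shows. Statements on the series, on what has been measured and on what is new or still open speak of the compounds shown alone.

Measured compounds:
- compound 1 `Cc1cccnc1-c1ccc(C(=O)Nc2ccc(C(C)(C)C)cc2)cc1`: 9 nM
- compound 2 `CC(C)(C)c1ccc(NC(=O)c2ccc(-c3ncccc3C#N)cc2)cc1`: 13 nM
- compound 3 `CC(C)(C)c1ccc(NC(=O)c2ccc(-c3ncccc3-c3ncc[nH]3)cc2)cc1`: 694 nM

In a functional assay for antagonist activity at transient receptor potential cation channel subfamily V member 1 (Rattus norvegicus) (a higher number here means a weaker inhibitor, a lower number a stronger inhibitor), compound 3 gives the highest of the three numbers. Its nearest neighbour is compound 2, where the step of a 53-fold higher number from compound 2 to compound 3 (1.73 log units; beyond the scatter) was recorded, and the step of a 77-fold higher number from compound 1 to compound 3 (1.89 log units; beyond the scatter) was larger still. Between compound 1 and compound 2 only a 1.4-fold higher number from compound 1 to compound 2 (0.16 log units; within the scatter) separates the two.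

Compound 4 `Cc1nnc(-c2cccnc2-c2ccc(C(=O)Nc3ccc(C(C)(C)C)cc3)cc2)o1` differs from compound 3 in one place: 5-methyl-1,3,4-oxadiazol-2-yl in place of 1H-imidazol-2-yl on an aromatic carbon. Among the compounds with values here, the steps that bear on this change are those from compound 1 and compound 2 to compound 3, both large, and both show that a five-membered aromatic ring at this carbon carries a much higher number in this assay than a methyl or a cyano group. Compound 4 keeps a five-membered aromatic ring at the same carbon, so a return to the level of compound 1 or compound 2 is not expected; a modest move downward from compound 3, within a wide range, is the best guess, amounting to a 2.3-fold lower number from compound 3 to compound 4 (0.36 log units; beyond the scatter). Compound 4 is therefore expected to give about 300 nM in this assay, between 60 nM and 1500 nM.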

Compound 4, half-maximal inhibitory concentration: 34 nM
Compound 4: the middle estimate sits 8.8-fold (0.95 log units) above what was measured; measured number below the stated range.
By their numbers in this assay, from the lowest: compounds 1 and 2 (each within the scatter of the next); then compound 4; then compound 3.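

In this assay, a five-membered aromatic ring at this carbon does not by itself bring a high number: 5-methyl-1,3,4-oxadiazol-2-yl in place of 1H-imidazol-2-yl gives a 20-fold lower number from compound 3 to compound 4 (1.31 log units; beyond the scatter), so the identity of the ring matters greatly. The oxadiazole recovers most of the gap but not all of it, with a 2.6-fold higher number from compound 2 to compound 4 (0.42 log units; beyond the scatter) and a 3.8-fold higher number from compound 1 to compound 4 (0.58 log units; beyond the scatter), both modest and beyond the scatter. No measurement shown explains the difference between the two rings.

The change removes a hydrogen-bond donor, adds hetero atoms to the ring and brings in a methyl all at once, and this single step cannot separate these differences. As far as these compounds go, how 1-methyl-1H-imidazol-2-yl or 1,3,4-oxadiazol-2-yl without its methyl would read at this carbon remains open.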